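Pyridine ether side chain: methoxypropoxy to benzyloxy

The source may report more compounds than this note shows. Statements on the series, on what has been measured and on what is new or still open speak of the compounds shown alone.

Measured so far in an assay on cells for antagonist activity at transient receptor potential cation channel subfamily V member 1 (Homo sapiens), read by FLIPR and calcium flux, with a stated time of 6 min; on this read-out higher numbers stand for weaker inhibition and lower numbers for stronger inhibition:
compound 1 `CCCCN(C)c1nc(C(C)(C)C)ccc1CNC(=O)C(C)c1ccc(NS(C)(=O)=O)c(F)c1` gives 1.2 nM
compound 2 `CCCCOc1nc(C(C)(C)C)ccc1CNC(=O)C(C)c1ccc(NS(C)(=O)=O)c(F)c1` gives 0.9 nM
compound 3 `COCCCOc1nc(C(C)(C)C)ccc1CNC(=O)C(C)c1ccc(NS(C)(=O)=O)c(F)c1` gives 5.6 nM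

Compound 3 gives the highest of the three numbers in this assay; the nearest is compound 1, as a 4.7-fold higher number from compound 1 to compound 3 (0.67 log units; beyond the scatter), and the furthest is compound 2, as a 6.2-fold higher number from compound 2 to compound 3 (0.79 log units; beyond the scatter). Compound 1 and compound 2 sit within the scatter of each other, a 1.3-fold lower number from compound 1 to compound 2 (0.12 log units; within the scatter).

Compound 4 `CC(C(=O)NCc1ccc(C(C)(C)C)nc1OCc1ccccc1)c1ccc(NS(C)(=O)=O)c(F)c1` is not yet measured. Its change from compound 3 is phenyl in place of 2-methoxyethyl on a saturated chain carbon bound to an oxygen on an aromatic ring. For the measured compounds named here, the step that bears most directly on it is the one into compound 3, a 6.2-fold higher number from compound 2 to compound 3 (0.79 log units; beyond the scatter), which shows that bringing in the methoxy raised the number beyond the scatter; compound 4 takes that methoxy away again. Nothing measured here tells what the phenyl itself does. Compound 4 is therefore expected to move back toward compound 2, an estimated 2.8-fold lower number from compound 3 to compound 4 (0.45 log units; beyond the scatter), though with wide uncertainty. The estimate for compound 4 is 2 nM, ranging from 0.6 nM to 8 nM.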

Compound 4, inhibition constant: 4.4 nM
Compound 4: middle estimate off by 2.2-fold (0.34 log units), on the low side; the measured number falls inside the stated range.
By their numbers in this assay, from the lowest: compounds 2 and 1 (each within the scatter of the next); then compounds 4 and 3 (each within the scatter of the next).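

In this assay the benzyloxy and 3-methoxypropoxy side chains cannot be told apart (a 1.3-fold lower number from compound 3 to compound 4 (0.10 log units; within the scatter)), so at this position a phenyl in place of the 2-methoxyethyl leaves the number where it was. Removing the methoxy is therefore not enough on its own to recover the values of the butoxy and butyl(methyl)amino compounds, as benzyloxy stays beyond the scatter from both (a 4.9-fold higher number from compound 2 to compound 4 (0.69 log units; beyond the scatter); a 3.7-fold higher number from compound 1 to compound 4 (0.56 log units; beyond the scatter)). No measurement at hand accounts for this gap.

Open, as far as these compounds go, is whether a cyclohexyl in place of the phenyl, or a longer chain such as 2-phenylethoxy, would return the number toward that of compound 2. Also open, from the compounds shown here alone, is whether benzyl(methyl)amino would track benzyloxy, as butyl(methyl)amino tracks butoxy.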